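A few compounds are considered here, and "the series" means these few. Any claim that something is new, unique, unknown or untested is made for them only; others in the source may bear on it.

In a functional assay on U-937 cells (Homo sapiens) for cytotoxicity, read by MTT assay, with a stated time of 24 h (on this read-out higher numbers stand for weaker inhibition and lower numbers for stronger inhibition), compound 2 (`CC(=O)Oc1c(Br)cc(Br)cc1Oc1ccc(Br)cc1Br`) gives 32.3 ug/mL and compound 1 (`CN1CCN(CCCCCOc2c(Br)cc(Br)cc2Oc2ccc(Br)cc2Br)CC1`) gives 49.1 ug/mL. Going by the values given here, these two values lie within the scatter of each other, so compound 2 is not separated from the only other measured compound. Compound 3 (`BrCCOc1c(Br)cc(Br)cc1Oc1ccc(Br)cc1Br`) has 2-bromoethyl in place of acetyl on an oxygen on an aromatic ring. Among the compounds with values here, no measured step covers this change, so the two values above are the only guide. The expected step of a 1.0-fold lower number from compound 2 to compound 3 (0.00 log units; within the scatter) stays within the scatter, with no firm direction. In this assay, compound 3 is estimated at 32 ug/mL, with an expected range of 15 ug/mL to 65 ug/mL.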

Compound 3, half-maximal inhibitory concentration: 32.5 ug/mL
Compound 3: middle estimate off by 1.0-fold (0.01 log units), on the low side, within the range that was stated.
By their numbers in this assay, from the lowest: compounds 2, 3 and 1 (each within the scatter of the next).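

In this assay, 2-bromoethyl in place of acetyl on an oxygen on an aromatic ring gives a 1.0-fold higher number from compound 2 to compound 3 (0.00 log units; within the scatter), so exchanging acetyl, with its double bond and hydrogen-bond acceptor, does not move the read-out beyond the scatter. Bromo in place of 3-(4-methylpiperazin-1-yl)propyl on a saturated chain carbon, two bonds along the chain from an oxygen on an aromatic ring, gives a 1.5-fold lower number from compound 1 to compound 3 (0.18 log units; within the scatter), which is also no separation. Nothing on hand explains why these steps stay within the scatter.

Open is whether a free hydroxyl or a carboxylic acid on this oxygen would give a value beyond the scatter of these compounds.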